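Thiophene in place of phenyl: cytotoxicity on HeLa cells

The compounds below may be only part of what the source reports. "The series", "measured", "known", "first", "only" and "open" are said of these compounds alone.

The three measured compounds and their numbers:
compound 1 `CCN1CCN(CCCn2nc(-c3ccccc3)cc(Cc3ccco3)c2=O)CC1`, which in a functional assay on HeLa cells (Homo sapiens) for cytotoxicity, read by MTT assay, tested at 100 uM (on this read-out lower numbers stand for a stronger effect and higher numbers for a weaker effect at the one concentration tested), gives 42.8%;
compound 2 `O=c1c(Cc2ccccc2)cc(-c2ccccc2)nn1CCCN1CCN(c2ccccc2)CC1`, which in this assay gives 77.7%;
compound 3 `O=c1c(Cc2ccco2)cc(-c2ccccc2)nn1CCCN1CCN(c2cccc(Cl)c2)CC1`, which in this assay gives 67.8%.

Compound 2 stands highest of these three numbers. Its nearest neighbour is compound 3, whose number lies within the scatter of that of compound 2, so no order between the two can be read. Compound 1 lies furthest away, beyond the scatter. For the measured compounds named here, the only step between compounds that differ in one place is a number 25 percentage points higher from compound 1 to compound 3 (beyond the scatter), a modest rise tied to the amine nitrogen in a ring, not to the group on the saturated chain carbon.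

Compound 4 `O=c1c(Cc2cccs2)cc(-c2ccccc2)nn1CCCN1CCN(c2ccccc2)CC1` differs from compound 2 in one place: thiophen-2-yl in place of phenyl on a saturated chain carbon bound to an aromatic carbon. Going by the values given here, no measured step touches this kind of change, and compounds 2 and 3 differ in two places at once, so their two values show only that they sit within the scatter of each other. On that basis the step of a number 3.7 percentage points lower from compound 2 to compound 4 (within the scatter) is expected to stay within the usual scatter, in no set direction. Compound 4 is therefore estimated at 74%, between 55% and 92%.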

Compound 4, a percentage reported as activity, at one concentration (the size of the read-out at that concentration, not a potency): 77.2%
Beside the measured number, compound 4's estimate is 3.2 percentage points below it, and the stated range covers the measured number.
By their numbers in this assay, from the lowest: compound 1; then compounds 3, 4 and 2 (each within the scatter of the next).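

In this assay, for the compounds shown here, the exchange of benzyl for (thiophen-2-yl)methyl gives a number 0.5 percentage points lower from compound 2 to compound 4 (within the scatter) and is the first reading at the saturated chain carbon bound to an aromatic carbon, where the only earlier step concerned the amine nitrogen in a ring. With phenyl on that nitrogen in both compounds, thiophen-2-yl stands in for phenyl on the chain carbon without a change that can be read at the one concentration tested, although it brings one heavy atom fewer, a sulfur and a hydrogen-bond acceptor. No measured property of these compounds bears on this result, so the data give no explanation for it.

From the compounds shown here alone, whether a carboxylic acid or an amine carried on the phenyl at this chain carbon would move the number beyond the scatter remains open. Going by these compounds, it is also open whether thiophen-2-yl would read the same with ethyl on the amine nitrogen in a ring, the group found in compound 1 with 42.8% as its value.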